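Cyano in Place of Ethynyl: An Expected Growth-Inhibition Value

A few compounds are considered here, and "the series" means these few. Any claim that something is new, unique, unknown or untested is made for them only; others in the source may bear on it.

Compound 2, `C#Cc1cc(-c2nc3ccccc3s2)ccc1N`, gives 49 nM in a functional assay on MCF7 cells (Homo sapiens) for inhibition, with a stated time of 72 h; on this read-out higher numbers stand for weaker inhibition of growth and lower numbers for stronger inhibition of growth.
Compound 3, `C#Cc1cc(-c2nc3c(F)cccc3s2)ccc1N`, gives 110 nM in this assay.
Compound 1, `C[Si](C)(C)C#Cc1cc(-c2nc3cc(F)ccc3s2)ccc1N`, gives 160 nM in this assay.

Compound 2 thus stands lowest of the three numbers; compound 3 follows with a 2.2-fold higher number from compound 2 to compound 3 (0.35 log units; beyond the scatter), and compound 1 shows the highest number. Compound 4, `N#Cc1cc(-c2nc3ccccc3s2)ccc1N`, differs from compound 2 by cyano in place of ethynyl on an aromatic carbon. Within the data shown here, no measured step touches this position: the only step on record, a 2.2-fold higher number from compound 2 to compound 3 (0.35 log units; beyond the scatter), concerns a fluoro on the shared core. The two groups are equal in size, so in this assay compound 4 is expected to stay close to compound 2, giving a 1.4-fold higher number from compound 2 to compound 4 (0.15 log units; within the scatter) at most modest. The estimate for compound 4 is 70 nM, within 25 nM to 200 nM.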

Compound 4, concentration for 50% growth inhibition: 580 nM
Compound 4: middle estimate off by 8.3-fold (0.92 log units), on the low side; measured number above the stated range.
By their numbers in this assay, from the lowest: compound 2; then compounds 3 and 1 (each within the scatter of the next); then compound 4.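

At this position, on an aromatic carbon ortho to an amino group, matching size does not make two groups interchangeable: cyano in place of ethynyl gives a 12-fold higher number from compound 2 to compound 4 (1.07 log units; beyond the scatter) in this assay, a large step. The counts show one difference in hydrogen-bond acceptors, with one on cyano and none on ethynyl, but no measurement shown links that difference to the step or otherwise explains it.

From the compounds shown here alone, it remains open whether a methyl or chloro group here would stay closer to compound 2. The compounds shown also do not tell whether the same change would have a similar effect on a fluoro-bearing core.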